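The source may hold more compounds than are shown below. What is called first, only, known or untested is meant among the compounds shown, and "the series" means these compounds.

In an ADME assay on HEp-2 cells (Homo sapiens) for cytotoxicity, read by MTT assay, with a stated time of 60 h (on this read-out lower numbers stand for higher toxicity in this test and higher numbers for lower toxicity in this test), compound 1 (`Cc1c(Br)cc2c(nc3n2[C@H]2OC[C@@H](OS(C)(=O)=O)[C@H]2OC3)c1Br`) gives 15600 nM as the lower of the two numbers at hand, which means the higher toxicity. That sets it apart, beyond the usual scatter, from compound 2 (`Cc1cc2nc3n(c2cc1C)[C@H]1OC[C@@H](O)[C@H]1OC3`) at 492000 nM on the same test. Compound 3 (`Cc1c(Br)cc2c(nc3n2[C@H]2OC[C@@H](OCc4ccccc4)[C@H]2OC3)c1Br`) keeps the core of compound 1 but has benzyl in place of methylsulfonyl on an oxygen on a saturated carbon. Going by the values given here, no measured pair shows this change, so only a small expected rise, about the size of the scatter, can be offered (a 1.9-fold higher number from compound 1 to compound 3 (0.28 log units; within the scatter)). In this assay the estimated value for compound 3 is 30000 nM (expected range 8000 nM to 120000 nM).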

Compound 3, half-maximal cytotoxic concentration: 25600 nM
Compound 3: middle estimate off by 1.2-fold (0.07 log units), on the high side; the range from low to high includes it.
By their numbers in this assay, from the lowest: compounds 1 and 3 (each within the scatter of the next); then compound 2.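

On an oxygen on a saturated carbon, benzyl in place of methylsulfonyl gives a 1.6-fold higher number from compound 1 to compound 3 (0.22 log units; within the scatter) in this assay, so this swap leaves the read-out within the scatter. The two groups differ clearly in what is counted, since benzyl brings a six-membered aromatic ring of carbon only and methylsulfonyl brings no ring. Nothing at hand explains why the numbers match. As far as these compounds go, whether an amine or a carboxylic acid in this place on the core of compound 1 would also fall within the scatter stays open.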